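This account rests on a few compounds, and the source may have more. Where it says the series, first, only, none or still open, it means among the compounds named here.

Compound 1 `CCCOC(=O)c1cccc(C(=O)Nc2cccc(-c3cc(C(=O)Nc4ccncc4F)ccc3CN)c2)c1` belongs to a pair of amide-linked analogues tested in an assay on cells for inhibition of Rho-associated protein kinase 2 (Homo sapiens), read by radiometric assay and 33P incorporation, in the presence of a further agent that is not named here; a lower number here means a stronger inhibitor, a higher number a weaker inhibitor. In this assay compound 1 gives 1.8 nM. Its companion, compound 2 `COC(=O)c1cccc(NC(=O)c2cccc(-c3cc(C(=O)Nc4ccncc4F)ccc3CN)c2)c1F`, gives 1.2 nM in this assay; the two numbers sit within the scatter of each other, so nothing separates them. The third member, compound 3 `COC(=O)c1ccc(C(=O)Nc2cccc(-c3cc(C(=O)Nc4ccncc4F)ccc3CN)c2)cc1`, has not yet been measured. It differs from compound 1 in one place: 4-(methoxycarbonyl)phenyl in place of 3-(propoxycarbonyl)phenyl on a carbonyl carbon whose other neighbours are an amide-type nitrogen. Going by the values given here, no measured pair shows the effect of this change, so any expectation rests on the closeness of compound 1 and compound 2 alone. A small step from compound 1 to compound 3 is expected, a 1.4-fold higher number from compound 1 to compound 3 (0.14 log units; within the scatter), with the direction uncertain. Compound 3 is therefore estimated to give 2.5 nM in this assay, with a range from 0.8 nM to 8 nM.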

Compound 3, half-maximal inhibitory concentration: < 1 nM
Compound 3: only a limit was reported; the forecaster's own chance of this, stated with the estimate: 2%; at least 2.5-fold (0.39 log units) between middle value and limit.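

Going by these compounds alone, the change of 3-(propoxycarbonyl)phenyl to 4-(methoxycarbonyl)phenyl on a carbonyl carbon gives the one step read at this position in this assay, an at least 1.8-fold lower number from compound 1 to compound 3 (0.25 log units; that floor lies within the scatter). Compound 3 gives < 1 nM, which is a limit of the assay and not a number. The change therefore brings no visible loss of inhibition, but the true size of the step stays unknown and its floor alone does not clear the scatter, and the reading is bounded by the assay itself: the limit of < 1 nM in this assay, at which 1 of the 3 values shown sits.

Both the length of the ester chain and the placement of the ester change at once between these compounds, so the compounds shown do not say which of the two carries the step, a question that 3-(methoxycarbonyl)phenyl would address. They also leave open how a carboxylic acid or an amine in place of the ester would behave in this assay.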